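Removing a Single Fluorine from a Kinase Inhibitor

A few compounds are considered here, and "the series" means these few. Any claim that something is new, unique, unknown or untested is made for them only; others in the source may bear on it.

Measured compounds:
Compound 1, `O=C(Nc1cc2cc[nH]c(=O)c2cc1Cl)C1CNCC1c1ccc(F)cc1`, 9 nM
Compound 2, `O=C(Nc1cc2cc[nH]c(=O)c2cc1Cl)[C@@H]1CCCNC1`, 47 nM

Both compounds were tested in an assay on isolated protein for inhibition of Rho-associated protein kinase 2 (Homo sapiens), read by a luciferase reporter; a higher number here means a weaker inhibitor, a lower number a stronger inhibitor. Compound 1 gives 9 nM, the lower of the two numbers, and so the stronger inhibitor of the pair. Compound 2 gives 47 nM, and the gap between these two values lies beyond the usual scatter of the measurement, so compound 1 stands clearly ahead of compound 2 in this assay.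

Compound 3, `O=C(Nc1cc2cc[nH]c(=O)c2cc1Cl)C1CNCC1c1ccccc1`, has not yet been measured. It differs from compound 1 in one place only: hydrogen in place of fluoro on an aromatic carbon. Put another way, the 4-fluorophenyl group of compound 1 becomes a plain phenyl group in compound 3; the rest of the shared core is untouched.

Going by the values given here, no pair of measured compounds shows what such a change does here, so the step can only be guessed. A change of a single fluorine to hydrogen is usually small, and the expected step from compound 1 to compound 3 is a 1.4-fold higher number from compound 1 to compound 3 (0.16 log units; within the scatter), within the scatter or a little toward weaker inhibition. Compound 3 is therefore expected to give about 13 nM in this assay, within a range from 5 nM to 35 nM.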

Compound 3, half-maximal inhibitory concentration: 6 nM
Beside the measured number, compound 3's estimate is 2.2-fold (0.34 log units) above it; the range from low to high includes it.
By their numbers in this assay, from the lowest: compounds 3 and 1 (each within the scatter of the next); then compound 2.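

Going by these compounds alone, this is the first direct reading of what happens at this aromatic carbon: in this assay, going from 4-fluorophenyl to phenyl gives a 1.5-fold lower number from compound 1 to compound 3 (0.18 log units; within the scatter), so the two compounds cannot be told apart. Within this pair, then, the fluoro group is not needed to keep the number where it stands, and the plain phenyl group serves as well as the 4-fluorophenyl group on the shared core. Nothing at hand explains why the two numbers sit so close together, and no supporting measurement bears on this result.

Only hydrogen and fluoro have been seen at this place, so a single pair cannot show whether the position accepts other groups in general, such as chloro, methoxy, an amine or a carboxylic acid. It also remains open whether the phenyl ring itself matters, since no compound shown differs from compound 3 by that ring alone.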